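Methylsulfonyl on the ring nitrogen of compound 1

The compounds below may be only part of what the source reports. "The series", "measured", "known", "first", "only" and "open" are said of these compounds alone.

In a functional assay on HCC827 cells (Homo sapiens) for antiproliferative activity, read by MTT assay, with a stated time of 72 h (on this read-out higher numbers stand for weaker inhibition and lower numbers for stronger inhibition), compound 1 `CN1CCN(c2ccc(Nc3ncc4nc(Nc5ccccc5)n([C@H]5CCNC5)c4n3)cc2)CC1` gives 530 nM. Two close relatives share its core. Compound 2 `CN1CCN(c2ccc(Nc3ncc4nc(Nc5ccc(F)cc5)n([C@H]5CCNC5)c4n3)cc2)CC1` gives 1220 nM, and compound 3 `CN1CCN(c2ccc(Nc3ncc4nc(Nc5ccc(F)cc5)n([C@H]5CCN(C(=O)OC(C)(C)C)C5)c4n3)cc2)CC1` gives 580 nM. Compound 1 and compound 3 lie within the usual scatter of each other, while compound 2 stands apart from both. Fluoro in place of hydrogen on an aromatic carbon gave a 2.3-fold higher number from compound 1 to compound 2 (0.36 log units; beyond the scatter).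

Compound 4 `CN1CCN(c2ccc(Nc3ncc4nc(Nc5ccccc5)n([C@H]5CCN(S(C)(=O)=O)C5)c4n3)cc2)CC1` has not yet been measured. It differs from compound 1 by methylsulfonyl in place of hydrogen on an amine nitrogen in a ring, (methylsulfonyl in place of hydrogen on an amine nitrogen in a ring). The nearest guide is a step at that same nitrogen, where tert-butoxycarbonyl in place of hydrogen gave a 2.1-fold lower number from compound 2 to compound 3 (0.32 log units; beyond the scatter). That step is modest, involves a different group and was taken with the fluoro present, so it carries over only loosely. For the measured compounds named here, it is also the only step of its kind available. A small move towards a lower number in this assay is therefore expected, possibly none beyond the scatter. The expected change is a 1.3-fold lower number from compound 1 to compound 4 (0.10 log units; within the scatter). For compound 4 the estimated value is 420 nM, with an expected range of 160 nM to 1100 nM.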

Compound 4, half-maximal inhibitory concentration: 17 nM
Compound 4: the middle estimate sits 25-fold (1.39 log units) above what was measured; the measured number lies below the stated range.
By their numbers in this assay, from the lowest: compound 4; then compounds 1 and 3 (each within the scatter of the next); then compound 2.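

Methylsulfonyl on this amine nitrogen in a ring gives a 31-fold lower number from compound 1 to compound 4 (1.49 log units; beyond the scatter) in this assay and so shows that a change at this position can have a large effect on the read-out, not only a modest one. For the compounds shown here, the only earlier change at this nitrogen, tert-butoxycarbonyl in place of hydrogen, gave a 2.1-fold lower number from compound 2 to compound 3 (0.32 log units; beyond the scatter) and was made with the fluoro present, so the two steps start from different compounds, but together they show that the group placed on this nitrogen can matter greatly. Nothing measured here explains why the methylsulfonyl step is so large.

The compounds shown leave open whether this large step belongs to methylsulfonyl alone or extends to related groups on the same nitrogen, such as ethylsulfonyl, phenylsulfonyl or a simple acetyl group. They also leave open whether methylsulfonyl would give a step of similar size on compound 2, where the fluoro is already present, as the only methylsulfonyl compound shown lacks that fluoro.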